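The compounds below may be only part of what the source reports. "The series", "measured", "known", "first", "only" and "open" are said of these compounds alone.

Of the compounds shown here, two have been measured so far. Compound 1 `COc1ccc(Nc2cc(Nc3ccc(Oc4ccncc4-c4cccnc4)c(F)c3)ncn2)cc1` gives 2140 nM in a functional assay on A549 cells (Homo sapiens) for cytotoxicity, read by MTT assay, with a stated time of 72 h (on this read-out higher numbers stand for weaker inhibition and lower numbers for stronger inhibition), and compound 2 `O=C(Nc1ccc(Oc2ccncc2-c2cccnc2)c(F)c1)C1=NN(c2ccccc2C(F)(F)F)c2ccccc2S1(=O)=O` gives 120 nM in the same assay. Compound 2 thus stands at the lower of the two numbers, and the gap to compound 1 lies beyond the usual scatter of the measurement.

Compound 3 `O=C(Nc1ccc(Oc2ccncc2-c2cccnc2)c(F)c1)C1=NN(c2cccc(F)c2)c2ccccc2S1(=O)=O` is the next step out from compound 2. The change is 3-fluorophenyl in place of 2-(trifluoromethyl)phenyl on a nitrogen on an aromatic ring in a ring; the rest of the molecule is kept as it is. Among the measured compounds shown here, no measured pair in this set shows the effect of exchanging one aryl group for another at that position, so the size of the step has to be guessed. The expectation is for a small loss, if anything, with a fair chance that the step from compound 2 to compound 3 falls within the scatter. Compound 3 is estimated at 220 nM, within a range of 60 nM to 800 nM, which corresponds to an expected step of a 1.8-fold higher number from compound 2 to compound 3 (0.26 log units; within the scatter).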

Compound 3, half-maximal inhibitory concentration: 900 nM
Beside the measured number, compound 3's estimate is 4.1-fold (0.61 log units) below it; the whole stated range lies below it.
By their numbers in this assay, from the lowest: compound 2; then compound 3; then compound 1.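

In this assay, among the compounds shown here, 3-fluorophenyl in place of 2-(trifluoromethyl)phenyl on the nitrogen gives a 7.5-fold higher number from compound 2 to compound 3 (0.88 log units; beyond the scatter), the first single change in this set whose effect can be read. With the rest of the molecule kept as it is, the number responds to which substituted phenyl group sits at this position, and the step lies beyond the scatter. No measurement shown gives a reason for this step.

The two groups differ both in their substituent and in where it stands on the phenyl ring, so the step cannot be assigned to either difference: 2-fluorophenyl or 3-(trifluoromethyl)phenyl would separate the two. From the compounds shown here alone, it also remains open how unsubstituted phenyl, or a benzyl group or an alkyl chain in place of the aromatic ring, would behave at this position.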